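Methyl on the phenol oxygen: from compound 3 to compound 4

The source may report more compounds than this note shows. Statements on the series, on what has been measured and on what is new or still open speak of the compounds shown alone.

The series is a shared core carrying an amino-linked aryl group that varies from compound to compound. Compound 1 `O=C1CCC(N2C(=O)c3ccc(Nc4ccccn4)cc3C2=O)C(=O)N1` carries pyridin-2-yl on that nitrogen, compound 2 `Cc1ccc(Nc2ccc3c(c2)C(=O)N(C2CCC(=O)NC2=O)C3=O)cc1` 4-methylphenyl and compound 3 `O=C1CCC(N2C(=O)c3ccc(Nc4ccc(O)cc4)cc3C2=O)C(=O)N1` 4-hydroxyphenyl. In an assay on FRT-Jurkat cells for inhibition of nuclear factor NF-kappa-B complex (Homo sapiens), read by flow cytometry, with a stated time of 24 h, tested at 10 uM (on this read-out higher numbers stand for more inhibition at the one concentration tested (going by the name of the read-out) and lower numbers for less inhibition), compound 1 gives 9%, compound 2 gives 5% and compound 3 gives 4%. All three numbers lie within the scatter of one another: the step of a number 4 percentage points lower from compound 1 to compound 2 (within the scatter), the step of a number 5 percentage points lower from compound 1 to compound 3 (within the scatter) and the step of a number 1 percentage points lower from compound 2 to compound 3 (within the scatter) are each within the scatter, so no ordering among the three compounds can be read from these numbers.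

Compound 4 `COc1ccc(Nc2ccc3c(c2)C(=O)N(C2CCC(=O)NC2=O)C3=O)cc1` is the next member. Its difference from compound 3 is methyl in place of hydrogen on an oxygen on an aromatic ring. Going by the values given here, none of the measured steps is the same change, but all three bear on it in the sense that every swap of the aryl group so far, including the swap of hydroxy for methyl on an aromatic carbon, has left the read-out in this assay unchanged within the scatter. A step no larger than the scatter is therefore expected here as well, with no preferred direction.

For compound 4 the expected value in this assay is 6%, with a range from -2% to 15%. That estimate corresponds to an expected step of a number 2 percentage points higher from compound 3 to compound 4 (within the scatter), which would remain within the scatter.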

Compound 4, a percentage reported as inhibition, at one concentration (the size of the read-out at that concentration, not a potency): 29%
For compound 4 the middle estimate is 23 percentage points below the measured one, outside the stated range (above it).
By their numbers in this assay, from the lowest: compounds 3, 2 and 1 (each within the scatter of the next); then compound 4.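

In this assay, going by these compounds alone, the methyl on the phenol oxygen gives a number 25 percentage points higher from compound 3 to compound 4 (beyond the scatter) and is the first change to lie beyond the scatter, so this position does respond to the aryl substituent even though the earlier swaps showed no ordering. The rise is also seen against the other two compounds, with methoxy in place of methyl on the aromatic carbon giving a number 24 percentage points higher from compound 2 to compound 4 (beyond the scatter) and 4-methoxyphenyl in place of pyridin-2-yl giving a number 20 percentage points higher from compound 1 to compound 4 (beyond the scatter) as the steps for those pairs; hydroxy and methyl on that carbon stay within the scatter of each other, so the shift is tied to the methoxy group rather than to any substituent placed there. No measurement here bears on the reason for this rise.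

On these data alone, whether the rise stops at methoxy or continues with ethoxy, a longer alkoxy chain, or a dimethylamino group at the same place remains open. The read-out comes from one concentration only, so these compounds give no potency, and a methoxy group elsewhere on the phenyl ring is also untested in the compounds shown here.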